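A Heteroaryl Amide Returns to the Weak End

The source may report more compounds than this note shows. Statements on the series, on what has been measured and on what is new or still open speak of the compounds shown alone.

Compound 2 `O=C(Nc1ccc(Cl)c(-c2nnc3c(Cl)cccn23)c1)c1cccc(Cl)c1` gives 66100 nM in a functional assay on MDA-MB-231 cells (Homo sapiens) for antiproliferative activity, read by MTT assay, with stated times of 72 h and 4 h; a lower number here means a stronger inhibitor, a higher number a weaker inhibitor. That is the highest of the two numbers measured; compound 3 `CS(=O)(=O)c1ccc(C(=O)Nc2ccc(Cl)c(-c3nnc4c(Cl)cccn34)c2)c(Cl)c1` gives 37200 nM in this assay, and the gap between them lies within the scatter. Compound 1 `Cc1nc(C(=O)Nc2ccc(Cl)c(-c3nnc4c(Cl)cccn34)c2)cs1` reaches only a limit of the assay, > 100000 nM, in this assay (the limit of > 100000 nM in this assay, at which 1 of the 3 values shown sits). Among the compounds with values here, the one measured step that touches compound 2 is an at least 1.5-fold lower number from compound 1 to compound 2 (0.17 log units; that floor lies within the scatter), a 3-chlorophenyl taking the place of a heteroaryl group on the carbonyl carbon and lowering the number to a degree whose floor is within the scatter.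

Compound 4 `O=C(Nc1ccc(Cl)c(-c2nnc3c(Cl)cccn23)c1)c1ccon1` reverses that sense of change: 1,2-oxazol-3-yl in place of 3-chlorophenyl on a carbonyl carbon. Since the earlier step toward an aromatic heteroaryl carbonyl group gave a limit in compound 1, compound 4 is expected to move back toward a higher number, by an estimated 1.8-fold higher number from compound 2 to compound 4 (0.26 log units; within the scatter), with a real chance that only a limit is reported. The estimate for compound 4 is 120000 nM, between 40000 nM and 400000 nM.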

Compound 4, half-maximal inhibitory concentration: > 100000 nM
Compound 4 ended at the assay's limit (the forecaster's own chance of this, stated with the estimate: 60%); the middle value does not contradict the limit.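

With 1,2-oxazol-3-yl in place of 3-chlorophenyl on the carbonyl carbon, this assay shows an at least 1.5-fold higher number from compound 2 to compound 4 (0.17 log units; that floor lies within the scatter). Compound 4 gives only a limit of the assay, > 100000 nM, and it is the second heteroaryl group on this carbonyl carbon to end at that limit, after compound 1: the limit of > 100000 nM in this assay, at which 2 of the 4 values shown sit. The step between compound 1 and compound 4 cannot be read, and the floor of the step to compound 4 does not by itself separate that compound from compound 2 beyond the scatter.

Going by these compounds, the true values of compound 1 and compound 4 remain open. It also remains open whether an amine such as piperidine or a carboxylic acid on this carbonyl carbon would give a readable number, and the compounds shown give no cause for any of these results.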